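Propanoyl to methoxyacetyl on the trimethoxyphenyl amide

The compounds below may be only part of what the source reports. "The series", "measured", "known", "first", "only" and "open" are said of these compounds alone.

Measured compounds:
- compound 1, `CCC(=O)N(Cc1ccc(OC)c(O)c1)c1cc(OC)c(OC)c(OC)c1`: 98 nM
- compound 2, `C/C=C/C(=O)N(Cc1ccc(OC)c(C)c1)c1cc(OC)c(OC)c(OC)c1`: 32900 nM
- compound 3, `C/C=C/C(=O)N(Cc1ccc(OC)c(Br)c1)c1cc(OC)c(OC)c(OC)c1`: 10500 nM

In a functional assay on KYSE-450 cells (Homo sapiens) for inhibition, read by MTT assay, with a stated time of 48 h (on this read-out lower numbers stand for stronger inhibition and higher numbers for weaker inhibition), compound 1 gives the lowest of the three numbers. Within the data shown here, compound 2 and compound 3 carry a crotonyl chain together with a methyl or bromo on the benzyl ring and both sit far higher; the single measured step, a 3.1-fold lower number from compound 2 to compound 3 (0.50 log units; beyond the scatter), concerns only that aromatic substituent and says nothing about the acyl chain.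

Compound 4, `COCC(=O)N(Cc1ccc(OC)c(O)c1)c1cc(OC)c(OC)c(OC)c1`, keeps the hydroxy-methoxybenzyl group of compound 1 and changes only the acyl chain: methoxy in place of methyl on a saturated chain carbon bound to a carbonyl carbon. Among the measured compounds shown here, no measured pair isolates a change on the saturated chain carbon bound to the carbonyl carbon, so the effect of this move cannot be read from the series; the hydroxy pattern that accompanies the lowest number is retained, which argues for staying near compound 1. The expected outcome for compound 4 in this assay is therefore a step of a 1.5-fold higher number from compound 1 to compound 4 (0.18 log units; within the scatter), within or close to the scatter, in no firm direction. The estimate for compound 4 is 150 nM, with a range from 40 nM to 600 nM.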

Compound 4, half-maximal inhibitory concentration: 460 nM
Beside the measured number, compound 4's estimate is 3.1-fold (0.49 log units) below it; the range from low to high includes it.
By their numbers in this assay, from the lowest: compound 1; then compound 4; then compound 3; then compound 2.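

In this assay, among these compounds, the saturated chain carbon bound to a carbonyl carbon proves sensitive to substitution: methoxy in place of methyl gives a 4.7-fold higher number from compound 1 to compound 4 (0.67 log units; beyond the scatter), the only measured step that isolates a change at this place on the acyl chain. Among the compounds shown here, the rest of the structure is the same in the pair, so the step belongs to this change alone, although the one swap brings in an oxygen, a hydrogen-bond acceptor and an extra heavy atom together, and a single pair cannot separate them. Nothing at hand accounts for the size or direction of this step.

Still open, from the compounds shown here alone, is whether the higher number follows the oxygen or the added chain length, which an ethyl, a hydroxy or a dimethylamino group in the same place would help to settle. Also open is how the crotonyl chain of compound 2 and compound 3 compares with the propanoyl chain of compound 1, as the compounds shown hold no pair that differs in the acyl chain alone.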